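Swapping a Basic Chain for a Pyridine on the Piperazine

The source may report more compounds than this note shows. Statements on the series, on what has been measured and on what is new or still open speak of the compounds shown alone.

Compound 1 `CC1=C(C(C)C(=O)NCCN(C)C)c2cc(F)ccc2/C1=C\c1ccc([S+](C)[O-])cc1` gives > 50000 nM in a functional assay on PC-3 cells (Homo sapiens) for inhibition, read by CellTiter-Glo, with a stated time of 72 h; a lower number here means that less compound is tolerated, a higher number that more compound is tolerated
Compound 2 `CC1=C(C(C)C(=O)N2CCN(CCCN(C)C)CC2)c2cc(F)ccc2/C1=C\c1ccc([S+](C)[O-])cc1` gives > 50000 nM in this assay

Both values are limits of the assay rather than numbers. For compound 1 the value > 50000 nM is a limit. For compound 2 the value > 50000 nM is likewise a limit, so compound 2 stands at the edge of what this assay can report. The step that the two limits leave unreadable from compound 1 to compound 2 cannot be sized, as the limit of > 50000 nM in this assay, at which 2 of the 2 values shown sit, describes.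

Compound 3 `CC1=C(C(C)C(=O)N2CCN(c3ccncc3)CC2)c2cc(F)ccc2/C1=C\c1ccc([S+](C)[O-])cc1` differs from compound 2 by pyridin-4-yl in place of 3-(dimethylamino)propyl on an amine nitrogen in a ring. For the measured compounds named here, the only measured step that bears on compound 3 is the unreadable one from compound 1 to compound 2, so no size or direction can be drawn from it. Given that compound 2 sits at the limit, compound 3 is expected to sit near that limit too, with the step of a number no higher from compound 2 to compound 3 (the limit leaves the size open) expected to be none beyond the scatter. The estimate for compound 3 is 50000 nM, in the range 15000 nM to 150000 nM.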

Compound 3, half-maximal cytotoxic concentration: 10500 nM
The estimate for compound 3 lay 4.8-fold (0.68 log units) above the measured number; the whole stated range lies above it.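

On the amine nitrogen of the piperazine, pyridin-4-yl in place of 3-(dimethylamino)propyl gives an at least 4.7-fold lower number from compound 2 to compound 3 (0.67 log units; beyond the scatter) in this assay, so a change at this position can bring the read-out to a measurable number. The leaving and entering groups have the same heavy-atom count, but one is an open chain and the other an aromatic ring. Against the shorter amide side chain, 4-(pyridin-4-yl)piperazin-1-yl in place of (2-(dimethylamino)ethyl)amino gives an at least 4.7-fold lower number from compound 1 to compound 3 (0.67 log units; beyond the scatter), and neither step has an exact size, because the two earlier compounds give only a limit: the limit of > 50000 nM in this assay, at which 2 of the 3 values shown sit.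

Still open, as far as these compounds go, is whether the aromatic ring alone is enough, which a plain phenyl on the same nitrogen would test. A pyridin-3-yl group there would show whether the place of the ring nitrogen matters.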